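Adding a Benzyl Group to the Ring Nitrogen

The source may report more compounds than this note shows. Statements on the series, on what has been measured and on what is new or still open speak of the compounds shown alone.

Of the compounds shown here, two have been measured so far in an assay on isolated protein for inhibition of Rho-associated protein kinase 1 (Homo sapiens), tested at 30 uM; a higher number here means more inhibition at the concentration tested (going by the name of the read-out), a lower number less inhibition. Compound 1, `c1ccc(Sc2ncnc3[nH]cnc23)cc1`, gives 33% in this assay. Compound 2, `Fc1ccc(Sc2ncnc3[nH]cnc23)cc1`, gives 37% in this assay. Among the compounds with values here, compound 2 thus holds the higher of the two numbers, but the only measured step, a number 4 percentage points higher from compound 1 to compound 2 (within the scatter), lies within the scatter, so the two compounds cannot be told apart on these numbers.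

The next compound is compound 3, `Fc1ccc(Sc2ncnc3c2ncn3Cc2ccccc2)cc1`. It differs from compound 2 in one place: benzyl in place of hydrogen on an aromatic nitrogen. Within the data shown here, no measured step concerns a change on this ring nitrogen; the one step that exists concerns a fluoro in place of hydrogen on an aromatic carbon, and it was small. Among the measured compounds shown here, there is therefore nothing in the numbers so far that points to a direction for this change, and the expectation rests on the assay itself and on the narrow spread of the two values measured.

For compound 3 the expected inhibition in this assay is 30%, with a range from 5% to 60%, which corresponds to an expected step of a number 7 percentage points lower from compound 2 to compound 3 (within the scatter).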

Compound 3, a percentage reported as inhibition, at one concentration (the size of the read-out at that concentration, not a potency): 5%
Beside the measured number, compound 3's estimate is 25 percentage points above it, and the stated range covers the measured number.
By their numbers in this assay, from the lowest: compound 3; then compounds 1 and 2 (each within the scatter of the next).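

The ring nitrogen is a place where a change shows clearly in this assay. Within the data shown here, putting benzyl on it gives a number 32 percentage points lower from compound 2 to compound 3 (beyond the scatter) and this is the first step beyond the scatter, whereas the earlier fluoro change on an aromatic carbon gave a number 4 percentage points higher from compound 1 to compound 2 (within the scatter) and left those two compounds indistinguishable. Two things happen in this single step, as the hydrogen leaves the nitrogen and a group of 7 heavy atoms with a six-membered aromatic ring arrives, and no measurement here says which of them matters or explains the drop.

On these data alone, what remains open is whether the loss follows from any group on this nitrogen or from benzyl in particular, which a compound carrying only a methyl on the same nitrogen, compared with compound 2, would help to separate. As far as these compounds go, it is also open whether a longer chain ending in an amine or a carboxylic acid at this position would give a number closer to that of compound 2 or stay as low as compound 3 at this single tested concentration.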